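Antiproliferative series: small alkyl additions on two cores

The source may report more compounds than this note shows. Statements on the series, on what has been measured and on what is new or still open speak of the compounds shown alone.

Measured so far in a functional assay on COR-L23 cells (Homo sapiens) for antiproliferative activity, read by CellTiter-Glo, with a stated time of 72 h; a higher number here means a weaker inhibitor, a lower number a stronger inhibitor:
- compound 1 `O=C(Nc1ccc(CN2Cc3ccccc3C2=O)cc1)N1CC(c2cccnc2)C1` gives 9.9 nM
- compound 2 `C[C@@H](c1ccc(NC(=O)N2CC(c3cccnc3)C2)cc1)N1Cc2ccccc2C1=O` gives 8 nM
- compound 3 `COc1nc2ccccc2n1Cc1ccc(NC(=O)N2CC(c3cccnc3)C2)cc1` gives 4.3 nM

Compound 1 and compound 2 share a core and differ by methyl in place of hydrogen on a saturated chain carbon bound to an amide-type nitrogen in a ring and an aromatic carbon; this step in this assay is a 1.2-fold lower number from compound 1 to compound 2 (0.09 log units; within the scatter). The difference between the core of compound 1 and the core of compound 3 is not broken down here. Compound 4 `CCOc1nc2ccccc2n1Cc1ccc(NC(=O)N2CC(c3cccnc3)C2)cc1` is not yet measured; it differs from compound 3 by methyl in place of hydrogen on a saturated chain carbon bound to an oxygen on an aromatic ring. This is the same kind of change as from compound 1 to compound 2, but the place differs: there the methyl enters on a saturated chain carbon bound to an amide-type nitrogen in a ring and an aromatic carbon, here on a saturated chain carbon bound to an oxygen on an aromatic ring. Because a 1.2-fold lower number from compound 1 to compound 2 (0.09 log units; within the scatter) stayed within the scatter, a similarly small step is expected, a 1.0-fold higher number from compound 3 to compound 4 (0.02 log units; within the scatter). Compound 4 is thus estimated at 4.5 nM in this assay, expected between 2 nM and 10 nM.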

Compound 4, half-maximal inhibitory concentration: 3.9 nM
Beside the measured number, compound 4's estimate is 1.2-fold (0.06 log units) above it, within the range that was stated.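

In this assay, methyl in place of hydrogen on a saturated chain carbon bound to an oxygen on an aromatic ring gives a 1.1-fold lower number from compound 3 to compound 4 (0.04 log units; within the scatter). Set beside the same change on the other core, the two steps do not differ: the same change on two cores in this assay, a 1.2-fold lower number (0.09 log units; within the scatter) from compound 1 to compound 2 and a 1.1-fold lower number (0.04 log units; within the scatter) from compound 3 to compound 4, 1.1-fold (0.05 log units) apart, within the scatter of two such steps. This shows that a single added methyl stays within the scatter on both cores, though at a different place on each, but with one pair per core it gives no rule for other cores, other places or larger groups.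

The compounds shown leave open whether a longer chain such as propoxy, or an amine in place of the ethoxy, would also stay within the scatter of compound 3.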